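Swapping an aryl group for cyclohexyl on a shared core

A few compounds are considered here, and "the series" means these few. Any claim that something is new, unique, unknown or untested is made for them only; others in the source may bear on it.

Compound 1 `Cc1ccc(S(=O)(=O)/N=C(/CCNC2=CC(=O)c3ccccc3C2=O)Nc2ccccc2[N+](=O)[O-])cc1` and compound 2 `COc1ccc(N/C(CCNC2=CC(=O)c3ccccc3C2=O)=N\S(=O)(=O)c2ccc(C)cc2)c(OC)c1` share a core and differ only in the group on one amine nitrogen. In a functional assay on DU-145 cells (Homo sapiens) for cytotoxicity, read by MTT assay, with a stated time of 48 h (on this read-out higher numbers stand for weaker inhibition and lower numbers for stronger inhibition), compound 1 gives 7590 nM, while compound 2 gives 67300 nM. Among the compounds with values here, the single step that has been measured is an 8.9-fold higher number from compound 1 to compound 2 (0.95 log units; beyond the scatter). On these two numbers compound 2 stands as the higher one, that is, the weaker inhibitor of the pair.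

Compound 3 `Cc1ccc(S(=O)(=O)/N=C(/CCNC2=CC(=O)c3ccccc3C2=O)NC2CCCCC2)cc1` is still to be measured. It differs from compound 2 in one place: cyclohexyl in place of 2,4-dimethoxyphenyl on an amine nitrogen. Within the data shown here, no measured step replaces an aromatic ring with a saturated ring on this nitrogen, so the only bearing comes from the measured step itself, which shows that this position is sensitive and that the 2,4-dimethoxyphenyl group sits at the weak end of what has been seen. Removing it is therefore expected to move the number down rather than up, but by an uncertain amount. The step from compound 2 to compound 3 is estimated as a 3.4-fold lower number from compound 2 to compound 3 (0.53 log units; beyond the scatter). For compound 3 the expected value in this assay is 20000 nM, with a range from 5000 nM to 80000 nM.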

Compound 3, half-maximal inhibitory concentration: 16600 nM
Beside the measured number, compound 3's estimate is 1.2-fold (0.08 log units) above it, within the range that was stated.
By their numbers in this assay, from the lowest: compound 1; then compound 3; then compound 2.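

Putting cyclohexyl on this amine nitrogen does not move the number in a single direction: in this assay there is a 4.1-fold lower number from compound 2 to compound 3 (0.61 log units; beyond the scatter) when it replaces 2,4-dimethoxyphenyl, but a 2.2-fold higher number from compound 1 to compound 3 (0.34 log units; beyond the scatter) when it replaces 2-nitrophenyl. The direction of this change therefore depends on which aromatic group leaves, and compound 3, with a non-aromatic ring in this place, falls between compound 1 and compound 2, so among these three compounds an aromatic ring at this nitrogen is neither needed to reach this range nor enough to give the lowest number. Nothing available explains why these numbers differ.

Three compounds cannot separate the effect of the ring from that of what it carries, and a plain phenyl group on the same nitrogen would show how much of the gap between compound 1 and compound 2 comes from the nitro and methoxy groups. As far as these compounds go, it also remains open how the number would respond to a group without any ring, such as an ethyl or a longer chain, or to a ring containing nitrogen, such as piperidine.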